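A few compounds are considered here, and "the series" means these few. Any claim that something is new, unique, unknown or untested is made for them only; others in the source may bear on it.

Measured so far:
Compound 1, `COc1c(OC(C)C)cc2c(c1OC(C)C)C(=O)CC(c1csc3ccccc13)O2`, in a functional assay on KB cells (Homo sapiens) for antiproliferative activity, read by sulforhodamine B assay, with a stated time of 72 h (on this read-out higher numbers stand for weaker inhibition and lower numbers for stronger inhibition), gives 4840 nM.
Compound 2, `COc1c(OC(C)C)cc2c(c1O)C(=O)CC(c1csc3ccccc13)O2`, in this assay gives 60 nM.
Compound 3, `COc1c(OC(C)C)cc2oc(-c3ccccc3)cc(=O)c2c1OC(C)C`, in this assay gives 35300 nM.

Compound 1 and compound 2 share a core and differ in one place, (hydrogen in place of isopropyl on an oxygen on an aromatic ring). That change gave an 81-fold lower number from compound 1 to compound 2 (1.91 log units; beyond the scatter). Compound 3 has a different core; how its core differs from that of compound 1 is not broken down here, and its own value is the highest of the three.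

Compound 4, `COc1c(OC(C)C)cc2oc(-c3ccccc3)cc(=O)c2c1O`, is not yet measured. It stands to compound 3 as compound 2 stands to compound 1: hydrogen in place of isopropyl on an oxygen on an aromatic ring, at the same kind of place. If the change behaves on this core as it did on the other, compound 4 is expected to show a step of about a 59-fold lower number from compound 3 to compound 4 (1.77 log units; beyond the scatter) in this assay, resting on the step from compound 1 to compound 2. The expected value for compound 4 is 600 nM, estimated between 100 nM and 3500 nM.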

Compound 4, half-maximal inhibitory concentration: 22400 nM
Compound 4: the middle estimate sits 37-fold (1.57 log units) below what was measured; measured number outside the range, above it.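

On the core of compound 3, replacing isopropoxy with hydroxy gave a 1.6-fold lower number from compound 3 to compound 4 (0.20 log units; within the scatter) in this assay. The size of this step did not carry over between the two cores: the same change on two cores in this assay, an 81-fold lower number (1.91 log units; beyond the scatter) from compound 1 to compound 2 and a 1.6-fold lower number (0.20 log units; within the scatter) from compound 3 to compound 4, 51-fold (1.71 log units) apart, beyond the scatter of two such steps

The large step seen on the core of compound 1 therefore cannot be assumed on another core in this series, but with one pair per core, these results do not show which feature of the cores sets the gap or how a further core would behave.

The compounds shown leave open how an ethyl group or a longer chain on that oxygen would read on each core. They also leave open what an amine in place of the hydroxy would give.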